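Aryl replacement on the shared core: thiophene step

The compounds below may be only part of what the source reports. "The series", "measured", "known", "first", "only" and "open" are said of these compounds alone.

For the measured compounds named here, compound 2 `COc1ccc(S(=O)(=O)N2CCc3cccc(-c4ccc(F)c(F)c4)c32)cc1` gives 45 nM in a functional assay on KB cells (Homo sapiens) for inhibition, with a stated time of 72 h (a higher number here means a weaker inhibitor, a lower number a stronger inhibitor), the lowest of the three numbers measured so far. Compound 1 `COc1ccc(S(=O)(=O)N2CCc3cccc(-c4ccc(N)cc4)c32)cc1` gives 249 nM in this assay, and compound 3 `COc1ccc(S(=O)(=O)N2CCc3cccc(-c4cccnc4)c32)cc1` gives 95.9 nM. Compound 4 `COc1ccc(S(=O)(=O)N2CCc3cccc(-c4cccs4)c32)cc1` is not yet measured; it differs from compound 2 in one place: thiophen-2-yl in place of 3,4-difluorophenyl on an aromatic carbon. Going by the values given here, the steps that bear on this are a 2.1-fold higher number from compound 2 to compound 3 (0.33 log units; beyond the scatter), a 5.5-fold lower number from compound 1 to compound 2 (0.74 log units; beyond the scatter) and a 2.6-fold lower number from compound 1 to compound 3 (0.41 log units; beyond the scatter): every exchange of the aryl group so far moved the number by a modest amount, and the one heteroaryl replacement of the 3,4-difluorophenyl raised it. A modest rise beyond the scatter is therefore expected for compound 4, a 2.1-fold higher number from compound 2 to compound 4 (0.32 log units; beyond the scatter). Compound 4 is estimated at 95 nM, with a range of 40 nM to 220 nM.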

Compound 4, half-maximal inhibitory concentration: 215 nM
Compound 4: the middle estimate sits 2.3-fold (0.35 log units) below what was measured; the measured number falls inside the stated range.
By their numbers in this assay, from the lowest: compound 2; then compound 3; then compounds 4 and 1 (each within the scatter of the next).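

In this assay, the two heteroaryl replacements of 3,4-difluorophenyl at this aromatic carbon are not interchangeable: a 4.8-fold higher number from compound 2 to compound 4 (0.68 log units; beyond the scatter), and thiophen-2-yl also separates from pyridin-3-yl, with a 2.2-fold higher number from compound 3 to compound 4 (0.35 log units; beyond the scatter). Thiophen-2-yl and 4-aminophenyl cannot be told apart here, with a 1.2-fold lower number from compound 1 to compound 4 (0.06 log units; within the scatter). Nothing on hand accounts for these differences.

Open, on these data alone, is whether the low number of compound 2 follows its fluorine atoms or its six-membered carbon ring, a question for plain phenyl or 4-fluorophenyl. Also open, as far as these compounds go, is how thiophen-3-yl or furan-2-yl would compare with thiophen-2-yl.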